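A few compounds are considered here, and "the series" means these few. Any claim that something is new, unique, unknown or untested is made for them only; others in the source may bear on it.

Measured compounds:
compound 1, `COc1ccccc1NC(=O)c1cc(NC(C)=O)ccc1Sc1ccc([N+](=O)[O-])cc1`, 171000 nM
compound 2, `COc1ccccc1NC(=O)c1cc(N)ccc1Sc1ccc([N+](=O)[O-])cc1`, 506000 nM
compound 3, `COc1ccccc1NC(=O)c1cc([N+](=O)[O-])ccc1Sc1ccc([N+](=O)[O-])cc1`, "not determined" (no result reported)

In an ADME assay on H9 cells (Homo sapiens) for cytotoxicity, read by MTT assay, with a stated time of 7 days (a lower number here means that less compound is tolerated, a higher number that more compound is tolerated), compound 1 gives 171000 nM, and compound 2 gives 506000 nM. For the measured compounds named here, the one step between them, a 3.0-fold higher number from compound 1 to compound 2 (0.47 log units; beyond the scatter), is a modest one, and it concerns the acetylamino group of the shared core rather than the position that changes here. Compound 3 carries a nitro group on that position, and in this assay compound 3 gives "not determined" (no result reported), so it stands nowhere on the scale set by compounds 1 and 2; its place can only be inferred from them.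

Compound 4, `COc1ccccc1NC(=O)c1cc(F)ccc1Sc1ccc([N+](=O)[O-])cc1`, differs from compound 3 by fluoro in place of nitro on an aromatic carbon, on an aromatic carbon of a six-membered aromatic ring of carbon only. Going by the values given here, no measured step bears directly on this exchange, and the one step in hand, from compound 1 to compound 2, touches a different group. With no starting value for compound 3, the expectation for compound 4 can only be anchored to the span covered by compounds 1 and 2, and no direction of change can be stated. In this assay compound 4 is therefore expected to give about 250000 nM, estimated to fall between 80000 nM and 800000 nM.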

Compound 4, half-maximal cytotoxic concentration: 502000 nM
Beside the measured number, compound 4's estimate is 2.0-fold (0.30 log units) below it, and the stated range covers the measured number.
By their numbers in this assay, from the lowest: compound 1; then compounds 4 and 2 (each within the scatter of the next).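

In this assay, the position para to a (4-nitrophenyl)sulfanyl group now carries three different measured substituents, and replacing amino with fluoro there gives a 1.0-fold lower number from compound 2 to compound 4 (0.00 log units; within the scatter), so the two groups cannot be told apart in this read-out. Replacing acetamido with fluoro gives a 2.9-fold higher number from compound 1 to compound 4 (0.47 log units; beyond the scatter), a modest step that matches the one seen earlier when the acetyl was removed, so compound 1 now stands apart from both compounds 2 and 4 as the compound with the lowest number, rather than resting on a single comparison. Nothing available accounts for why the acetamido compound differs from the other two, and the result stands only as an observation.

The exchange of nitro for fluoro itself cannot be read, as compound 3 has no number to start from, so the place of the nitro group among these substituents stays unknown. Going by these compounds, it also remains open whether other groups at this position, such as a chlorine, a methoxy group or a carboxylic acid, would sit with compounds 2 and 4 or with compound 1.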